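This account rests on a few compounds, and the source may have more. Where it says the series, first, only, none or still open, it means among the compounds named here.

For the measured compounds named here, the three compounds measured so far share one core and differ only in the groups hung on it. Compound 1 `COc1cccc(-c2nc3c(c(C)nn3-c3ccccc3)c(-c3ccccc3O)c2C#N)c1` was run in an ADME assay on BJ cells (Homo sapiens) for cytotoxicity, with a stated time of 72 h; on this read-out lower numbers stand for an effect already at smaller amounts and higher numbers for an effect only at larger amounts of compound; in this assay compound 1 gives only a limit, > 23000 nM, and no number. Compound 2 `CCc1ccc(-c2nc3c(c(C)nn3-c3ccccc3)c(-c3ccccc3C#N)c2C#N)cc1` likewise gives a limit, > 20000 nM, in this assay. Compound 3 `CCc1ccc(-c2nc3c(c(C)nn3-c3ccccc3)c(-c3ccccc3OC(F)(F)F)c2C#N)cc1` also gives a limit, > 20000 nM, in this assay. Going by the values given here, the one change between measured compounds, trifluoromethoxy in place of cyano on an aromatic carbon, gives a step that the two limits leave unreadable from compound 2 to compound 3. Among the compounds with values here, compound 1 therefore stands exactly where the others stand: the limit of > 20000 nM in this assay, at which 2 of the 3 values shown sit, and the limit of > 23000 nM in this assay, at which 1 of the 3 values shown sits, are all the numbers show, and no compound can be placed above or below another.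

Compound 4 `Cc1nn(-c2ccccc2)c2nc(-c3ccc(S(C)(=O)=O)cc3)c(C#N)c(-c3ccccc3O)c12` differs from compound 1 by 4-(methylsulfonyl)phenyl in place of 3-methoxyphenyl on an aromatic carbon. Within the data shown here, no measured step covers this change, and the single measured step is unreadable, so nothing here points to a shift in either direction in this assay. Compound 4 is therefore expected to come out at the limit once more. The step from compound 1 to compound 4 that this expectation means is estimated as a step that the limit leaves unreadable from compound 1 to compound 4. The estimate for compound 4 in this assay is 25000 nM, within a range from 10000 nM to 60000 nM, and most likely reported as a limit rather than a number.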

Compound 4, half-maximal effective concentration: > 20000 nM
Compound 4: no number, only a limit (the forecaster's own chance of this, stated with the estimate: 85%); the middle value is on the limit's open side.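

For the compounds shown here, compound 1 and compound 4 each give only a limit in this assay, so the step between them cannot be read and this result adds no new step. The compounds shown leave open whether changing the groups on the shared core moves the value at all, as the values mostly sit at one limit: the limit of > 20000 nM in this assay, at which 3 of the 4 values shown sit.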